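This account rests on a few compounds, and the source may have more. Where it says the series, first, only, none or still open, it means among the compounds named here.

Compound 1 `ClC(Cl)(Cl)c1nc(Oc2cccc(Br)c2)c2ccccc2n1`: in an ADME assay on HepG2 cells (Homo sapiens) for cytotoxicity, read by MTT assay, with a stated time of 72 h (on this read-out higher numbers stand for lower toxicity in this test and lower numbers for higher toxicity in this test), compound 1 gives 36700 nM.
Compound 3 `CC(=O)c1cccc(Oc2nc(C(Cl)(Cl)Cl)nc3ccccc23)c1`: in this assay compound 3 gives 1000 nM.
Compound 2 `N#Cc1ccc(Oc2nc(C(Cl)(Cl)Cl)nc3ccccc23)cc1`: in this assay compound 2 gives only a limit, > 8000 nM.

Within the data shown here, of the two numbers, compound 3 stands lowest, and its only measured neighbour is compound 1, a step of a 37-fold lower number from compound 1 to compound 3 (1.56 log units; beyond the scatter). Compound 4 `COc1cccc(Oc2nc(C(Cl)(Cl)Cl)nc3ccccc23)c1` is the next one to measure. It differs from compound 3 by methoxy in place of acetyl on an aromatic carbon. Among the measured compounds shown here, no measured step exchanges acetyl for methoxy, so the one bearing step is the large change seen in a 37-fold lower number from compound 1 to compound 3 (1.56 log units; beyond the scatter) at the same position, which shows that a group at this position can shift the number a long way. For compound 4 the expected result is 8000 nM, within 1500 nM to 40000 nM. This estimate means an expected step of an 8.0-fold higher number from compound 3 to compound 4 (0.90 log units; beyond the scatter).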

Compound 4, half-maximal cytotoxic concentration: 500 nM
Estimate against measurement, compound 4: 16-fold (1.20 log units) above; the measured number lies below the stated range.
By their numbers in this assay, from the lowest: compounds 4 and 3 (each within the scatter of the next); then compound 1.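

In this assay, the exchange of acetyl for methoxy gives a 2.0-fold lower number from compound 3 to compound 4 (0.30 log units; within the scatter), so this assay does not separate these two groups at this position. The exchange of bromo for methoxy gives a 73-fold lower number from compound 1 to compound 4 (1.87 log units; beyond the scatter), which means that among compounds 1, 3 and 4, the bromo compound alone stands apart, with both other groups far lower. Nothing measured here explains that gap. On these data alone, what an amine, a carboxylic acid or a longer chain would give at this position remains open.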